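Swapping Methylsulfonyl for Tetrazolyl on a Second Core

The compounds below may be only part of what the source reports. "The series", "measured", "known", "first", "only" and "open" are said of these compounds alone.

Compound 1, `CC(C)c1noc(N2CCC([C@H]3C[C@H]3COCc3ccc(S(C)(=O)=O)cc3F)CC2)n1`, gives 3.8 in a physicochemical assay for lipophilicity, read by HPLC, at pH 7; a higher number here means a more lipophilic compound, a lower number a more polar compound.
Compound 2, `CC(C)c1noc(N2CCC([C@H]3C[C@H]3COCc3ccc(-n4cnnn4)cc3F)CC2)n1`, gives 3.9 in this assay.
Compound 3, `COCc1cnc(N2CCC([C@H]3C[C@H]3COCc3ccc(S(C)(=O)=O)c(F)c3)CC2)nc1`, gives 3.5 in this assay.

Compound 1 and compound 2 share one core and differ only by 1H-tetrazol-1-yl in place of methylsulfonyl on an aromatic carbon. The step this made in this assay was a number 0.10 log units higher from compound 1 to compound 2 (within the scatter), so the two numbers cannot be told apart. Compound 3 rests on a second core; how that core differs from the core of compound 1 is not broken down here. Compound 4, `COCc1cnc(N2CCC([C@H]3C[C@H]3COCc3ccc(-n4cnnn4)c(F)c3)CC2)nc1`, is not yet measured. It differs from compound 3 by 1H-tetrazol-1-yl in place of methylsulfonyl on an aromatic carbon. Within the data shown here, this is the same kind of change as the one between compound 1 and compound 2, though the place is not identical: in compound 2 the entering group is meta to a fluoro group, in compound 4 it is ortho to a fluoro group. The earlier instance gave a number 0.10 log units higher from compound 1 to compound 2 (within the scatter). On that basis compound 4 is expected to show a step of a number 0.10 log units higher from compound 3 to compound 4 (within the scatter) in this assay. Compound 4 is therefore estimated at 3.6, most likely between 3.3 and 3.9.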

Compound 4, distribution coefficient: 3.7
Beside the measured number, compound 4's estimate is 0.10 log units below it; the range from low to high includes it.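

In this assay swapping methylsulfonyl for 1H-tetrazol-1-yl gave a number 0.20 log units higher from compound 3 to compound 4 (within the scatter) on the second core and a number 0.10 log units higher from compound 1 to compound 2 (within the scatter) on the core of compound 1 so in neither pair can the two numbers be told apart. This shows the change carrying across these two cores with no step beyond the usual scatter, even though the place is not identical, with the entering group in compound 4 ortho to a fluoro group and para to a large group. Two pairs do not make a rule for other cores, however, and nothing available here explains why the change reads this way.

Still open, going by these compounds, is how a carboxylic acid or an amine would read in place of methylsulfonyl on either core, set against these two groups. Also open, on these data alone, is whether the same swap would again leave the number indistinguishable on a third core or in a different kind of assay.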